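The source may hold more compounds than are shown below. What is called first, only, known or untested is meant among the compounds shown, and "the series" means these compounds.

In a functional assay on A549 cells (Homo sapiens) for cytotoxicity, read by resazurin assay, with a stated time of 72 h (on this read-out lower numbers stand for stronger inhibition and higher numbers for weaker inhibition), compound 1 (`N#Cc1cc(-c2ccccc2)n(-c2ccccn2)c1N`) gives 32000 nM and compound 2 (`N#Cc1cc(-c2ccccc2)n(-c2ccc(Br)cc2)c1N`) gives 4600 nM. Compound 3 (`Nc1c(-c2nc3ccccc3[nH]2)cc(-c2ccccc2)n1-c1ccccn1`), which carries 1H-benzimidazol-2-yl in place of cyano, gives 8000 nM. That value lies within the usual scatter of compound 2, while the change from cyano amounts to a 4.0-fold lower number from compound 1 to compound 3 (0.60 log units; beyond the scatter).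

Compound 4 (`Nc1c(-c2nc3ccccc3[nH]2)cc(-c2ccccc2)n1-c1cccc(Br)c1`) keeps the 1H-benzimidazol-2-yl group and alters only the substituent on the aromatic nitrogen: 3-bromophenyl in place of pyridin-2-yl on an aromatic nitrogen. The nearest measured precedent is a 7.0-fold lower number from compound 1 to compound 2 (0.84 log units; beyond the scatter), where 4-bromophenyl replaced pyridin-2-yl on that same nitrogen, with cyano still on the core. That precedent differs in two ways, since it has 4-bromophenyl rather than 3-bromophenyl and lacks the 1H-benzimidazol-2-yl group. Going by the values given here, no measured compound carries 3-bromophenyl, and no measured pair tests this exchange with 1H-benzimidazol-2-yl present. A step in the same direction but somewhat smaller therefore seems likely, and the expected change is a 3.6-fold lower number from compound 3 to compound 4 (0.56 log units; beyond the scatter). The estimate for compound 4 is 2200 nM, with an expected range of 700 nM to 6500 nM.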

Compound 4, half-maximal inhibitory concentration: 13500 nM
Beside the measured number, compound 4's estimate is 6.1-fold (0.79 log units) below it, and the stated range ends below it.
By their numbers in this assay, from the lowest: compounds 2, 3 and 4 (each within the scatter of the next, the first and the last beyond it); then compound 1.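

On the 3-bromophenyl exchange at the aromatic nitrogen, with 1H-benzimidazol-2-yl on the core, this assay shows a 1.7-fold higher number from compound 3 to compound 4 (0.23 log units; within the scatter), so compounds 3 and 4 cannot be told apart. The earlier exchange of pyridin-2-yl at this nitrogen, a 7.0-fold lower number from compound 1 to compound 2 (0.84 log units; beyond the scatter), therefore does not carry over to this pair, although that step also had 4-bromophenyl as the entering group and cyano on the core. No measurement available here accounts for the difference between the two steps.

On these data alone, it remains open whether the bromine placement or the 1H-benzimidazol-2-yl group separates the two steps, a question that 4-bromophenyl with 1H-benzimidazol-2-yl, or 3-bromophenyl with cyano, would address. As far as these compounds go, how an unsubstituted phenyl or a 3-chlorophenyl group on this nitrogen would read in this assay also remains open.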